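The source may report more compounds than this note shows. Statements on the series, on what has been measured and on what is new or still open speak of the compounds shown alone.

Measured compounds in a functional assay on MGC-803 cells (Homo sapiens) for antiproliferative activity, read by CCK-8 assay, with a stated time of 72 h; on this read-out higher numbers stand for weaker inhibition and lower numbers for stronger inhibition:
- compound 1 `CC(=O)N1CC=C(c2ccn3c(-c4ccc(NC(=O)c5ccc([N+](=O)[O-])o5)cc4)cnc3c2)CC1` gives 940 nM
- compound 2 `O=C(Nc1ccc(-c2cnc3cc(N4CCN(C5CC5)CC4)ccn23)cc1)c1ccc([N+](=O)[O-])o1` gives 1650 nM
- compound 3 `O=C(Nc1ccc(-c2cnc3cc(N4CCCC4)ccn23)cc1)c1ccc([N+](=O)[O-])o1` gives 1150 nM

Compound 3 holds the second highest number of the three, with compound 1 nearest and compound 2 furthest; all three sit within the scatter of one another, so no order among them can be read from these numbers.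

Compound 4 `O=C(Nc1ccc(-c2cnc3cc(N4CCC4)ccn23)cc1)c1ccc([N+](=O)[O-])o1` differs from compound 3 only in the ring on the shared core: azetidin-1-yl in place of pyrrolidin-1-yl on an aromatic carbon.

Within the data shown here, the steps that bear on this position are the two already seen there. a 1.2-fold higher number from compound 1 to compound 3 (0.09 log units; within the scatter) and a 1.4-fold lower number from compound 2 to compound 3 (0.16 log units; within the scatter) both replaced one saturated amine ring by another on the same aromatic carbon, and neither moved the number beyond the scatter. Three different amine rings at this position thus gave numbers within the scatter of each other. Shrinking the ring from pyrrolidin-1-yl to azetidin-1-yl is a change of the same kind, and on this evidence no step beyond the scatter is expected in this assay in either direction.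

The number for compound 4 is therefore estimated at 1200 nM, with a range of 550 nM to 2600 nM, which means an expected step of a 1.0-fold higher number from compound 3 to compound 4 (0.02 log units; within the scatter).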

Compound 4, half-maximal inhibitory concentration: > 5000 nM
Compound 4 ended at the assay's limit (the forecaster's own chance of this, stated with the estimate: 3%); middle value at least 4.1-fold (0.61 log units) away from the limit.
By their numbers in this assay, from the lowest: compounds 1, 3 and 2 (each within the scatter of the next). At a limit, above all of these: compound 4.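

In this assay, azetidin-1-yl in place of pyrrolidin-1-yl gives an at least 4.3-fold higher number from compound 3 to compound 4 (0.63 log units; beyond the scatter), and azetidin-1-yl in place of 4-cyclopropylpiperazin-1-yl gives an at least 3.0-fold higher number from compound 2 to compound 4 (0.48 log units; beyond the scatter). Azetidin-1-yl in place of the group on compound 1 gives an at least 5.3-fold higher number from compound 1 to compound 4 (0.72 log units; beyond the scatter), so this position does respond to the group it carries, although the three earlier groups stayed within the scatter of one another. Compound 4 stands at a limit of the assay rather than at a number, so the true size of these steps is not known: the limit of > 5000 nM in this assay, at which 1 of the 4 values shown sits.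

With a single four-membered ring shown, the compounds do not tell whether this drop belongs to ring size in general or to azetidin-1-yl alone. A piperidin-1-yl ring or an open-chain dimethylamino group on the same aromatic carbon would show how far the tolerated groups extend.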